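The source may hold more compounds than are shown below. What is called first, only, known or untested is meant among the compounds shown, and "the series" means these compounds.

Compound 1 `CC[C@H](C)[C@H](N)CN(C(=O)[C@@H]1C[C@H]1c1ccc(OC)cc1)c1ccc(-c2ccccc2)cc1` reaches in a functional assay for agonist activity at G protein-coupled receptor 88 (Homo sapiens), read by HTRF and cAMP accumulation (on this read-out lower numbers stand for an effect already at smaller amounts and higher numbers for an effect only at larger amounts of compound), only a limit of > 25000 nM. Compound 2 `CC[C@H](C)[C@H](N)CN(C(=O)[C@@H]1C[C@H]1c1cc(F)ccc1F)c1ccc(-c2ccccc2)cc1` gives in this assay 770 nM.

Among the compounds with values here, compound 2 therefore stands as the sole compound with a number in this assay; the other value shown is a limit, (the limit of > 25000 nM in this assay, at which 1 of the 2 values shown sits), so it cannot be placed relative to compound 2 more closely than that.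

Compound 3 `CC[C@H](C)[C@H](N)CN(C(=O)[C@@H]1C[C@H]1c1cc(F)cc(F)c1)c1ccc(-c2ccccc2)cc1` differs from compound 2 by 3,5-difluorophenyl in place of 2,5-difluorophenyl on a saturated ring carbon. Within the data shown here, the one measured step that touches this position is the change on the same saturated ring carbon, an at least 32-fold lower number from compound 1 to compound 2 (1.51 log units; beyond the scatter), which shows that swapping the aryl group there can shift the number strongly. That step, however, exchanged a methoxy group for two fluorines, whereas here only the fluorines move on the ring, so its size gives a scale of what is possible rather than a direction.

Compound 3 is therefore expected to lie near compound 2, with a modest loss more likely than a gain: an estimate of 1500 nM, within 400 nM to 6000 nM, which corresponds to an expected step of a 1.9-fold higher number from compound 2 to compound 3 (0.29 log units; within the scatter).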

Compound 3, half-maximal effective concentration: 960 nM
Compound 3: middle estimate off by 1.6-fold (0.19 log units), on the high side, and the stated range covers the measured number.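

In this assay, the two fluorines can sit as in the 2,5-difluorophenyl or the 3,5-difluorophenyl group on this saturated ring carbon with no change beyond the scatter: a 1.2-fold higher number from compound 2 to compound 3 (0.10 log units; within the scatter). The arrangement of the fluorines on the aryl ring therefore made no measurable difference between these two compounds, a finer question than the earlier exchange of 4-methoxyphenyl for 2,5-difluorophenyl could address. A second difluorophenyl group also gives a large step away from the 4-methoxyphenyl group, an at least 26-fold lower number from compound 1 to compound 3 (1.41 log units; beyond the scatter), so the large step is not tied to one fluorine arrangement, though its true size stays unknown because compound 1 is recorded only as a limit: the limit of > 25000 nM in this assay, at which 1 of the 3 values shown sits.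

These three compounds cannot separate the effect of losing the methoxy group from that of gaining the fluorines, a question that an unsubstituted phenyl or a monofluorophenyl group on the same carbon would bear on. Going by these compounds, it also remains open whether other groups on this aryl ring, such as chlorine, trifluoromethyl or a nitrile, would behave like the two fluorines.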